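Dimethoxyphenyl replaces chlorobenzyl on the thiadiazole core

A few compounds are considered here, and "the series" means these few. Any claim that something is new, unique, unknown or untested is made for them only; others in the source may bear on it.

Measured compounds:
Compound 1 `C=C(Br)C(=O)Nc1cccc(-c2cn3nc(-c4ccc(F)cc4)sc3n2)c1`: 870 nM
Compound 2 `C=C(Br)C(=O)Nc1cccc(-c2cn3nc(Cc4ccc(Cl)cc4)sc3n2)c1`: 2700 nM

Of the compounds shown here, two sharing a common core have been measured in a functional assay on HeLa cells (Homo sapiens) for inhibition, read by cell counting, with a stated time of 4 days; on this read-out lower numbers stand for stronger inhibition and higher numbers for weaker inhibition. Compound 1 `C=C(Br)C(=O)Nc1cccc(-c2cn3nc(-c4ccc(F)cc4)sc3n2)c1` gives 870 nM in this assay, and compound 2 `C=C(Br)C(=O)Nc1cccc(-c2cn3nc(Cc4ccc(Cl)cc4)sc3n2)c1` gives 2700 nM. Compound 2 therefore stands at the highest number of the two, with compound 1 the nearest at a lower number. Going by the values given here, the single measured step, a 3.1-fold higher number from compound 1 to compound 2 (0.49 log units; beyond the scatter), was a modest rise on exchanging a 4-fluorophenyl group for a 4-chlorobenzyl group.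

Compound 3 `C=C(Br)C(=O)Nc1cccc(-c2cn3nc(-c4ccc(OC)c(OC)c4)sc3n2)c1` is not yet measured. It differs from compound 2 as follows: 3,4-dimethoxyphenyl in place of 4-chlorobenzyl on an aromatic carbon. Among the compounds with values here, the only step that bears on this change is the one from compound 1 to compound 2, which went up when a phenyl group became a benzyl group. Since compound 3 again carries a phenyl group on that carbon, as compound 1 does, the number in this assay is expected to fall by about the same size, a 2.7-fold lower number from compound 2 to compound 3 (0.43 log units; beyond the scatter), although a result within the scatter cannot be ruled out. Compound 3 is therefore estimated at 1000 nM, with a range from 350 nM to 3000 nM.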

Compound 3, half-maximal inhibitory concentration: 610 nM
Estimate against measurement, compound 3: 1.6-fold (0.21 log units) above; the range from low to high includes it.
By their numbers in this assay, from the lowest: compounds 3 and 1 (each within the scatter of the next); then compound 2.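

In this assay, the 3,4-dimethoxyphenyl group brings a 4.4-fold lower number from compound 2 to compound 3 (0.65 log units; beyond the scatter), so a second phenyl-type group at this carbon, next to the ring sulfur and the ring nitrogen, separates from the 4-chlorobenzyl group by a step beyond the scatter. The replacement of 4-fluorophenyl by 3,4-dimethoxyphenyl gives a 1.4-fold lower number from compound 1 to compound 3 (0.15 log units; within the scatter), which lies within the scatter, so among these three compounds both phenyl-bearing compounds have lower numbers than the benzyl-bearing compound 2, with no compound going against that pattern and with this position accepting two quite different substitution patterns on the phenyl ring without a step beyond the scatter. No measurement at hand accounts for these differences, and the change from compound 2 to compound 3 alters the link to the ring and the ring substituents together, so the two contributions cannot be separated.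

The compounds shown leave open how a 3,4-dimethoxybenzyl group or an unsubstituted phenyl group would read at this carbon, which would help to separate those two contributions. They also leave open how a group of another kind, such as a morpholine, a carboxylic acid or a longer alkyl chain, would behave in this position.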